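This account rests on a few compounds, and the source may have more. Where it says the series, first, only, none or still open, it means among the compounds named here.

Working notes on the series. Compound 3 `CNC(=O)c1cc(C(=O)NC2CC2)cn(Cc2ccc(F)cc2)c1=O` carries a 4-fluorophenyl on a saturated chain carbon bound to an aromatic nitrogen. In a physicochemical assay for solubility (a lower number here means a less soluble compound, a higher number a more soluble compound), compound 3 gives >= 162 ug/mL, which is a limit of the assay and not a number. Compound 1 `CNC(=O)c1cc(C(=O)NC2CC2)cn(Cc2ccc3nc[nH]c3c2)c1=O` bears 1H-benzimidazol-6-yl at the same place; in this assay compound 1 gives >= 163 ug/mL, again a limit. Compound 2 `CNC(=O)c1cc(C(=O)NC2CC2)cn(Cc2ccc(OC)cc2)c1=O` has 4-methoxyphenyl there, and in this assay compound 2 gives >= 143 ug/mL, also a limit. With all three values sitting at limits, the steps a step that the two limits leave unreadable from compound 1 to compound 3, a step that the two limits leave unreadable from compound 1 to compound 2 and a step that the two limits leave unreadable from compound 2 to compound 3 cannot be sized, so none of them reads as a change beyond the scatter. Compound 4 `CNC(=O)c1cc(C(=O)NC2CC2)cn(Cc2cccc3cn[nH]c23)c1=O` differs from compound 3 by 1H-indazol-7-yl in place of 4-fluorophenyl on a saturated chain carbon bound to an aromatic nitrogen. The nearest comparison is compound 1, whose 1H-benzimidazol-6-yl is likewise a fused bicyclic heteroaryl at this place and which sits at the limit of >= 163 ug/mL in this assay, at which 1 of the 3 values shown sits. The step of an at least 1.0-fold lower number from compound 3 to compound 4 (0.03 log units; that floor lies within the scatter) is therefore expected to stay within the scatter. Compound 4 is estimated at 150 ug/mL, with a range from 60 ug/mL to 250 ug/mL, and a further limit is the likelier outcome.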

Compound 4, solubility: >= 181 ug/mL
Compound 4: only a limit was reported (the forecaster's own chance of this, stated with the estimate: 65%); middle value at least 1.2-fold (0.08 log units) from the limit.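

In this assay compound 4 gives >= 181 ug/mL, a limit and not a number; with compound 1, compound 2 and compound 3 also at limits, none of the steps to compound 4 can be read. The compounds shown leave open whether these four groups differ at all in this read-out.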